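Replacing isopropyl with 4-fluorobenzyl on the ring nitrogen

This account rests on a few compounds, and the source may have more. Where it says the series, first, only, none or still open, it means among the compounds named here.

compound 1 `CC(C)c1onc(-c2c(Cl)cccc2Cl)c1COc1ccc(-c2nc3ccc(C(=O)O)cc3n2C(C)C)cc1` — 3.39 nM
compound 2 `CCC(CC)n1c(-c2ccc(OCc3c(-c4c(Cl)cccc4Cl)noc3C(C)C)cc2F)nc2ccc(C(=O)O)cc21` — 1.3 nM

In an assay on Huh-7 cells for agonist activity at Bile acid receptor (Homo sapiens), read by a luciferase reporter (a lower number here means that less compound is needed, a higher number that more compound is needed for the effect), compound 1 stands highest of the two numbers; compound 2 gives the lower number, and the gap lies beyond the scatter. The two differ in more than one place, so no single step can be read from them. Compound 3 `CC(C)c1onc(-c2c(Cl)cccc2Cl)c1COc1ccc(-c2nc3ccc(C(=O)O)cc3n2Cc2ccc(F)cc2)cc1` is not yet measured. It differs from compound 1 by 4-fluorobenzyl in place of isopropyl on an aromatic nitrogen. Nothing measured isolates a change at this nitrogen, so no direction beyond the scatter is expected; the expected step is a 1.1-fold lower number from compound 1 to compound 3 (0.05 log units; within the scatter). Compound 3 is expected to give 3 nM in this assay, with a range from 1 nM to 9 nM.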

Compound 3, half-maximal effective concentration: 3.31 nM
Beside the measured number, compound 3's estimate is 1.1-fold (0.04 log units) below it; the measured number falls inside the stated range.
By their numbers in this assay, from the lowest: compound 2; then compounds 3 and 1 (each within the scatter of the next).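

Among the compounds shown here, the first single change at the aromatic nitrogen gives, in this assay, a 1.0-fold lower number from compound 1 to compound 3 (0.01 log units; within the scatter). At this position, therefore, 4-fluorobenzyl, which adds a six-membered aromatic ring of carbon only, is not separated from isopropyl in this read-out. No measurement at hand accounts for this match.

Still open, from the compounds shown here alone, is how an amine, a carboxylic acid or a longer chain on this nitrogen would read. Compound 2 differs from compound 1 in more than one place, so what lies behind its lower number cannot be read from these compounds.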